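The compounds below may be only part of what the source reports. "The series", "measured", "known", "first", "only" and "open" are said of these compounds alone.

Working notes on the series: the step in question runs from compound 2 `O=C(N/N=C/c1cccc(Cl)c1Cl)Nc1ccc(Oc2ccnc3[nH]ccc23)c(F)c1` to compound 4 `O=C(N/N=C/c1ccc(O)cc1O)Nc1ccc(Oc2ccnc3[nH]ccc23)c(F)c1`. In a functional assay on A549 cells (Homo sapiens) for antiproliferative activity, read by MTT assay, with a stated time of 72 h (a lower number here means a stronger inhibitor, a higher number a weaker inhibitor), compound 2 is reported as "not active" (no number reported), so it offers no single number from which to measure a step. The structural change is 2,4-dihydroxyphenyl in place of 2,3-dichlorophenyl on a carbon with a double bond to nitrogen, with the shared core left untouched.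

Within the data shown here, one measured step bears on this, and it also concerns a substituent on the aromatic ring of the same side chain. Compound 1 `O=C(N/N=C/c1ccc([N+](=O)[O-])cc1)Nc1ccc(Oc2ccnc3[nH]ccc23)c(F)c1` gives 20 nM, while compound 3 `COc1ccc(/C=N/NC(=O)Nc2ccc(Oc3ccnc4[nH]ccc34)c(F)c2)cc1` gives 3980 nM. That is a 200-fold higher number from compound 1 to compound 3 (2.30 log units; beyond the scatter), a large step, with methoxy in place of nitro on an aromatic carbon. Activity in this series can therefore move far with that ring's substituents, and a large change from compound 2 is possible.

Its size cannot be stated, as compound 2 has no number. The direction expected is towards measurable activity, though a second result without a number remains possible. Compound 4 carries oxygen on the ring, as does compound 3 at 3980 nM, so a value closer to that one than to the far lower figure for compound 1 at 20 nM is expected. In this assay, compound 4 is expected at 2000 nM, with an estimated range of 200 nM to 20000 nM.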

Compound 4, half-maximal inhibitory concentration: 5840 nM
Compound 4: the middle estimate sits 2.9-fold (0.47 log units) below what was measured; the measured number falls inside the stated range.
By their numbers in this assay, from the lowest: compound 1; then compounds 3 and 4 (each within the scatter of the next).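

In this assay compound 4 gives 5840 nM as a measured number, so 2,4-dihydroxyphenyl on this carbon yields a value where 2,3-dichlorophenyl in compound 2 yielded none, and the step between those two cannot be read. The change of 4-methoxyphenyl to 2,4-dihydroxyphenyl gives a 1.5-fold higher number from compound 3 to compound 4 (0.17 log units; within the scatter) and so does not separate these two groups, whereas the change of 4-nitrophenyl to 2,4-dihydroxyphenyl gives a 290-fold higher number from compound 1 to compound 4 (2.47 log units; beyond the scatter) and leaves 4-nitrophenyl as the only group shown here with a number far from the others. Nothing at hand explains either the gap to compound 1 or the missing number for compound 2.

The compounds shown leave open whether 4-aminophenyl or 4-carboxyphenyl on this carbon would give a number near that of compound 1 or near those of compound 3 and compound 4. They also leave open whether the low number of compound 1 belongs to the nitro group as such or to the place it holds on the ring, and whether chlorine elsewhere on the ring would also give no number.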